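This account rests on a few compounds, and the source may have more. Where it says the series, first, only, none or still open, it means among the compounds named here.

Measured compounds:

compound 1, `CCC(=O)c1sc2nc(-c3cccs3)ccc2c1N` — in a functional assay on WI-38 VA13 cells (Homo sapiens) for cytotoxicity (on this read-out higher numbers stand for an effect only at larger amounts of compound and lower numbers for an effect already at smaller amounts), compound 1 gives 0.89 ug/mL
compound 2, `CC(C)(C)C(=O)c1sc2nc(-c3cccs3)ccc2c1N` — in this assay compound 2 gives 0.57 ug/mL
compound 3, `Nc1c(C(=O)c2cccc(Br)c2)sc2nc(-c3cccs3)ccc12` — in this assay compound 3 gives 0.5 ug/mL

All three share one core and differ only in the group attached to the carbonyl carbon. Compound 3 has the lowest of the three numbers, but its distance to the others is small: the step of a 1.8-fold lower number from compound 1 to compound 3 (0.25 log units; within the scatter) and the step of a 1.1-fold lower number from compound 2 to compound 3 (0.06 log units; within the scatter) both stay within the scatter, as does the step of a 1.6-fold lower number from compound 1 to compound 2 (0.19 log units; within the scatter). So far, then, the group on the carbonyl carbon has not shifted the read-out beyond what repeated measurements would show.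

Compound 4, `Nc1c(C(=O)c2ccc(F)cc2)sc2nc(-c3cccs3)ccc12`, is not yet measured. It differs from compound 3 by 4-fluorophenyl in place of 3-bromophenyl on a carbonyl carbon. The measured steps that bear on this all exchange the group on the carbonyl carbon, and none of them moved the number beyond the scatter, even when a chain was swapped for a ring. Swapping one six-membered aromatic ring for another is a smaller change than any of those, so no step beyond the scatter is expected in this assay, in either direction. Compound 4 is therefore estimated at 0.6 ug/mL, with a range from 0.3 ug/mL to 1.2 ug/mL. This estimate means a step of a 1.2-fold higher number from compound 3 to compound 4 (0.08 log units; within the scatter), expected to lie within the scatter.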

Compound 4, half-maximal effective concentration: 1.8 ug/mL
Beside the measured number, compound 4's estimate is 3.0-fold (0.48 log units) below it; the measured number lies above the stated range.
By their numbers in this assay, from the lowest: compounds 3, 2 and 1 (each within the scatter of the next); then compound 4.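

In this assay, the group on the carbonyl carbon can move the number beyond the scatter after all, and the step of a 3.6-fold higher number from compound 3 to compound 4 (0.56 log units; beyond the scatter) shows this for a change between two phenyl groups that carry the same counts of heavy atoms, rings, hydrogen-bond donors and acceptors. The 4-fluorophenyl group also sets its compound apart from those with the two non-aromatic groups, with the step of a 3.2-fold higher number from compound 2 to compound 4 (0.50 log units; beyond the scatter) and the step of a 2.0-fold higher number from compound 1 to compound 4 (0.31 log units; beyond the scatter) both beyond the scatter, so a chain-for-ring exchange at this place is not always as quiet as the first three compounds suggested. Nothing measured on these compounds gives a reason for these steps.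

Two things change at once in the step to 4-fluorophenyl, the halogen on the ring and where it sits, and only 4-bromophenyl or 3-fluorophenyl on the carbonyl carbon could tell these apart. Going by these compounds, how an unsubstituted phenyl, or a ring carrying an amine or a carboxylic acid, would read at this place also remains open.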